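Replacing the furan of compound 3 with an oxime ether

This account rests on a few compounds, and the source may have more. Where it says the series, first, only, none or still open, it means among the compounds named here.

The three measured compounds share a core that carries an imidazoline-bearing side chain and differ only in the aromatic substituent placed on the benzene ring. Compound 1 `Cc1noc(-c2ccccc2NCC2=NCCN2)n1` and compound 2 `Cc1nc(-c2ccccc2NCC2=NCCN2)no1` carry the two isomeric methyl-oxadiazoles. In a functional assay for activation of Alpha-1D adrenergic receptor (Homo sapiens) (on this read-out higher numbers stand for an effect only at larger amounts of compound and lower numbers for an effect already at smaller amounts), compound 1 reaches only a limit, < 5020 nM. In this assay compound 2 likewise reaches only a limit, < 5020 nM. Compound 3 `Cc1ccc(-c2ccccc2NCC2=NCCN2)o1` carries the 5-methylfuran-2-yl group; in this assay compound 3 also gives a limit, < 2000 nM. Because of the limit of < 5020 nM in this assay, at which 2 of the 3 values shown sit, and the limit of < 2000 nM in this assay, at which 1 of the 3 values shown sits, the steps a step that the two limits leave unreadable from compound 1 to compound 2, a step that the two limits leave unreadable from compound 1 to compound 3 and a step that the two limits leave unreadable from compound 2 to compound 3 cannot be sized; compound 3 therefore stands at a limit that is tighter than the other two, without a readable difference.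

Compound 4 `CO/N=C(\C)c1ccccc1NCC1=NCCN1` arises from compound 3 by a group of 5 heavy atoms (3 carbon, 1 nitrogen, 1 oxygen; no ring) in place of a group of 6 heavy atoms (5 carbon, 1 oxygen; one five-membered aromatic ring with 1 hetero atom), on an aromatic carbon. Within the data shown here, none of the measured steps gives a readable size, so no direction beyond the scatter can be claimed for this change. Compound 4 is expected to give about 1000 nM in this assay, within 150 nM to 6000 nM, which means an expected step that the limit leaves unreadable from compound 3 to compound 4.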

Compound 4, half-maximal effective concentration: < 5020 nM
Compound 4: a limit, no number; the forecaster's own chance of this, stated with the estimate: 45%; the middle value is on the limit's open side.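

In this assay compound 4 gives only a limit, < 5020 nM. Among these compounds, no step to compound 4 from compound 1, compound 2 or compound 3 can be read. The compounds shown leave open whether these four substituents on the shared core differ at all on this read-out.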